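Hydroxyalkyl side-chain variants: step from compound 2 to compound 4

A few compounds are considered here, and "the series" means these few. Any claim that something is new, unique, unknown or untested is made for them only; others in the source may bear on it.

The series keeps one shared core and varies the chain bound to its aromatic nitrogen. Compound 1 `OC(CCn1nc2c(Br)c(Br)c(Br)c(Br)c2n1)c1ccc(F)cc1`, compound 2 `C[C@@H](O)CCn1nc2c(Br)c(Br)c(Br)c(Br)c2n1` and compound 3 `OC(CCn1nc2c(Br)c(Br)c(Br)c(Br)c2n1)c1ccccc1` have been measured. In a functional assay on MCF7 cells (Homo sapiens) for antiproliferative activity, read by MTT assay, with a stated time of 24 h, tested at 25 uM (a higher number here means a weaker effect of the compound at the concentration tested, a lower number a stronger effect), compound 1 gives 101%, compound 2 gives 105% and compound 3 gives 99%. Within the data shown here, the single one-place step measured so far, a number 2 percentage points lower from compound 1 to compound 3 (within the scatter), lies within the scatter. Compound 2 holds the highest of the three numbers, with compound 1 nearest and compound 3 furthest, yet both gaps lie within the scatter, so no order among the three can be read. All three sit at a level that means no effect at the concentration tested.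

Compound 4 `OCC(O)Cn1nc2c(Br)c(Br)c(Br)c(Br)c2n1` is not yet measured. The change is 1,2-dihydroxyethyl in place of 2-hydroxypropyl on a saturated chain carbon bound to an aromatic nitrogen. Among the measured compounds shown here, no measured step touches this chain; the only step, from compound 1 to compound 3, concerns the fluoro and was within the scatter. With every measured number close together, no shift beyond the scatter is expected in this assay. The estimate for compound 4 is 100% with a range from 88% to 112%, which means an expected step of a number 5 percentage points lower from compound 2 to compound 4 (within the scatter).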

Compound 4, a percentage reported as activity, at one concentration (the size of the read-out at that concentration, not a potency): 156%
Estimate against measurement, compound 4: 56 percentage points below; measured number outside the range, above it.
By their numbers in this assay, from the lowest: compounds 3, 1 and 2 (each within the scatter of the next); then compound 4.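

In this assay, among these compounds, the chain on the saturated carbon bound to an aromatic nitrogen proves able to move the read-out: 1,2-dihydroxyethyl in place of 2-hydroxypropyl gives a number 51 percentage points higher from compound 2 to compound 4 (beyond the scatter), the first step beyond the scatter, and its direction is towards a weaker effect. The two groups hold 4 heavy atoms each, but the entering group has 2 carbon and 2 oxygen atoms against 3 carbon and 1 oxygen, 2 hydrogen-bond donors and 2 acceptors against 1 of each, and no defined stereocentre against 1, so this single step cannot be assigned to any one of these differences. No evidence at hand bears on the origin of this step.

The compounds shown leave open whether any change of this chain can lower the number and so give a stronger effect at the concentration tested. Also open, from the compounds shown here alone, is where an amine or a carboxylic acid in place of the added hydroxyl, or a longer chain carrying two hydroxyl groups, would fall relative to compound 2 and compound 4.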